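Trimming the Chain on a Shared Core

The source may hold more compounds than are shown below. What is called first, only, known or untested is meant among the compounds shown, and "the series" means these compounds.

The series shares a core carrying a chain on a saturated carbon bound to an aromatic nitrogen. In a functional assay for inhibition, with Homo sapiens as the target (on this read-out higher numbers stand for weaker inhibition and lower numbers for stronger inhibition), compound 2 `CCCc1nc(C)c2cnn(C/C=C/C(=O)OCC)c(=O)n12` gives only the limit > 48000 nM. Compound 1 `C=CCn1ncc2c(C)nc(C(C)C)n2c1=O` likewise reaches only the limit > 48000 nM in this assay. Compound 3 `C=CCn1nc(C)c2c(C)nc(CCC)n2c1=O` gives 69000 nM; > 48000 nM (2 entries) in this assay, as the several entries of compound 3 in this assay, 69000 nM; > 48000 nM (2 entries) shows. Across the series, (the limit of > 48000 nM in this assay, at which 2 of the 3 values shown sit). Compound 4 `C=CCn1ncc2c(C)nc(CCC)n2c1=O` differs from compound 2 by vinyl in place of 2-(ethoxycarbonyl)ethenyl on a saturated chain carbon bound to an aromatic nitrogen. Within the data shown here, no measured pair shows this change, so its size cannot be read from the data. Every measured compound sits in the weak range of this assay, and compound 4 is expected to remain in that weak range, with an expected step that the limit leaves unreadable from compound 2 to compound 4. Compound 4 is estimated at about 60000 nM in this assay, within 30000 nM to 150000 nM, quite possibly reported only as a limit.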

Compound 4, half-maximal inhibitory concentration: 40000 nM
Beside the measured number, compound 4's estimate is 1.5-fold (0.18 log units) above it, and the stated range covers the measured number.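

Replacing 2-(ethoxycarbonyl)ethenyl with vinyl on a saturated chain carbon bound to an aromatic nitrogen gives an at least 1.2-fold lower number from compound 2 to compound 4 (0.07 log units; that floor lies within the scatter) in this assay. Propyl in place of isopropyl on an aromatic carbon gives an at least 1.2-fold lower number from compound 1 to compound 4 (0.07 log units; that floor lies within the scatter), so neither change shows a real gain, and the smaller vinyl chain leaves the compound in the weak range. Compound 1 and compound 2 each stand only at a limit, so both steps are floors and not sizes: the limit of > 48000 nM in this assay, at which 2 of the 4 values shown sit.

From the compounds shown here alone, the true size of either step stays open. So does whether a carboxylic acid, an amine or a longer chain on that saturated chain carbon would lift the series out of the weak range.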